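Swapping the chain end group of compound 2

A few compounds are considered here, and "the series" means these few. Any claim that something is new, unique, unknown or untested is made for them only; others in the source may bear on it.

compound 1 `N#Cc1nc2c(-c3nc4ccccc4[nH]3)c(N)n(CCO)c2nc1C#N`: > 50000 nM (a limit of the assay, not a number)
compound 2 `CN1CCN(CCCn2c(N)c(-c3nc4ccccc4[nH]3)c3nc(C#N)c(C#N)nc32)CC1`: 5750 nM

Both compounds were tested in a functional assay on A549 cells (Homo sapiens) for antiproliferative activity, read by MTT assay, with a stated time of 48 h; a lower number here means a stronger inhibitor, a higher number a weaker inhibitor. Going by the values given here, compound 2 holds the only true number in this small set, since the other entry is a limit. The next compound to consider is compound 3 `CCN(CC)CCCCn1c(N)c(-c2nc3ccccc3[nH]2)c2nc(C#N)c(C#N)nc21`. It carries (diethylamino)methyl in place of 4-methylpiperazin-1-yl on a saturated chain carbon, three bonds along the chain from an aromatic nitrogen, which can also be read as 3-(4-methylpiperazin-1-yl)propyl changing to 4-(diethylamino)butyl: (diethylamino)methyl in place of 4-methylpiperazin-1-yl on a saturated chain carbon, three bonds along the chain from an aromatic nitrogen.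

Among the compounds with values here, only one measured step bears on this change, an at least 8.6-fold lower number from compound 1 to compound 2 (0.93 log units; beyond the scatter). That step was at least modest in size, and it replaced hydroxy with (4-methylpiperazin-1-yl)methyl. Within the data shown here, it shows what the loss of a hydroxy end does, but no measured step exchanges one amino end group for another. Compound 3 keeps an amino end group, so the gain seen in compound 2 is expected to persist. The expected change is a 1.2-fold lower number from compound 2 to compound 3 (0.06 log units; within the scatter), which is not expected to lie beyond the scatter. Compound 3 is estimated at 5000 nM, with an expected range from 1800 nM to 16000 nM.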

Compound 3, half-maximal inhibitory concentration: 5750 nM
Beside the measured number, compound 3's estimate is 1.2-fold (0.06 log units) below it, within the range that was stated.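

In this assay, one amino end group gave way to another with no readable effect: the exchange gave no change at the digits printed from compound 2 to compound 3 (within the scatter). At this level of activity, then, the chain end does not depend on the 4-methylpiperazin-1-yl ring, since the open-chain 4-(diethylamino)butyl group serves equally well. The earlier gain over the hydroxy end now rests on two different amino end groups rather than one, with an at least 8.6-fold lower number from compound 1 to compound 3 (0.93 log units; beyond the scatter), and neither amine-bearing compound goes against this, though the value of compound 1 is a limit of the assay and not a number: the limit of > 50000 nM in this assay, at which 1 of the 3 values shown sits.

The change from compound 2 to compound 3 removes the ring and lengthens the chain in one move, so a compound with a 3-(diethylamino)propyl chain would be needed to tell the two apart, and the flat result may hide two effects that cancel. The compounds shown also leave open how a morpholine or a primary amine would read at the chain end, and whether a hydroxy end on a butyl chain would stay at the level of compound 1.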